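The compounds below may be only part of what the source reports. "The series", "measured", "known", "first", "only" and "open" are said of these compounds alone.

Measured in an ADME assay on MCF-10A cells (Homo sapiens) for inhibition, with a stated time of 48 h; on this read-out higher numbers stand for weaker inhibition and lower numbers for stronger inhibition:
compound 1 `O=C(Nc1ccc(Br)cc1)N1CCC[C@H]1c1nc(-c2ccccc2)no1` gives only a limit, > 50000 nM.
compound 2 `O=C(Nc1ccc(OC(F)(F)F)cc1)N1CCC[C@H]1c1nc(-c2ccccc2)no1` gives only a limit, > 50000 nM.
compound 3 `O=C(Nc1ccc(Cl)cc1)N1CCC[C@H]1c1nc(-c2ccccc2Br)no1` gives only a limit, > 50000 nM.

Compound 3 thus stands at the limit of > 50000 nM in this assay, at which 3 of the 3 values shown sit, so no number for it is known. For the measured compounds named here, the only single-point step among the measured compounds, a step that the two limits leave unreadable from compound 1 to compound 2, changes the substituent on the anilide ring, not the phenyl on the five-membered ring, and both of its ends are limits.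

Compound 4 `O=C(Nc1ccc(Cl)cc1)N1CCC[C@H]1c1nc(-c2ccc(Br)cc2)no1` differs from compound 3 by 4-bromophenyl in place of 2-bromophenyl on an aromatic carbon. Going by the values given here, no measured step bears on this change, and no step has been readable. The expectation for compound 4 in this assay is therefore a value at or beyond the limit, a step that the limit leaves unreadable from compound 3 to compound 4, not readable as a change; compound 4 is estimated at 100000 nM, range 30000 nM to 400000 nM.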

Compound 4, half-maximal inhibitory concentration: > 50000 nM
Compound 4 was reported as a limit (the forecaster's own chance of this, stated with the estimate: 85%); the middle value does not contradict the limit.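

The step from compound 3 to compound 4 cannot be read, because both values are limits: the limit of > 50000 nM in this assay, at which 4 of the 4 values shown sit.

The compounds shown leave open whether any change to the shared core alters inhibition in this assay, since none has a numerical value.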